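Benzothiazole amide series: aryl swap at the second amide

A few compounds are considered here, and "the series" means these few. Any claim that something is new, unique, unknown or untested is made for them only; others in the source may bear on it.

Measured so far:
- compound 1, `Cc1ccccc1C(=O)Nc1ccc2nc(NC(=O)C3CCCCC3)sc2c1`, a functional assay on WI-38 VA13 cells (Homo sapiens) for cytotoxicity; on this read-out higher numbers stand for an effect only at larger amounts of compound and lower numbers for an effect already at smaller amounts: 0.085 ug/mL
- compound 2, `CC(=O)Nc1ccc2nc(NC(=O)C3CCCCC3)sc2c1`, this assay: 2.7 ug/mL

Compound 1 stands lowest of the two numbers in this assay; its nearest neighbour is compound 2, and the step of a 32-fold higher number from compound 1 to compound 2 (1.50 log units; beyond the scatter). For the measured compounds named here, that step exchanges the whole aromatic ring on the carbonyl carbon for a methyl, so it is the only measured step that touches the same place as the change now in question, though it is not the same change.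

Compound 3 is `O=C(Nc1ccc2nc(NC(=O)C3CCCCC3)sc2c1)c1cccnc1Cl`. It differs from compound 1 by 2-chloropyridin-3-yl in place of 2-methylphenyl on a carbonyl carbon. Here the ring is kept and only its make-up changes, whereas the measured step removed the ring altogether. The large loss seen from compound 1 to compound 2 therefore sets an outer bound rather than a forecast; an aryl for aryl swap is expected to move far less. Going by the values given here, no measured pair shows the effect of a pyridine nitrogen or a chlorine in this position, so direction is uncertain; a step near or modestly beyond the scatter, towards a higher number, is expected: a 1.8-fold higher number from compound 1 to compound 3 (0.25 log units; within the scatter). Compound 3 is thus estimated at 0.15 ug/mL, within 0.04 ug/mL to 0.6 ug/mL.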

Compound 3, half-maximal effective concentration: 0.075 ug/mL
For compound 3 the middle estimate is 2.0-fold (0.30 log units) above the measured one; the measured number falls inside the stated range.
By their numbers in this assay, from the lowest: compounds 3 and 1 (each within the scatter of the next); then compound 2.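

In this assay the aryl exchange reads as a 1.1-fold lower number from compound 1 to compound 3 (0.05 log units; within the scatter) and so leaves 2-methylphenyl and 2-chloropyridin-3-yl on this carbonyl carbon indistinguishable, even though the entering group brings 1 nitrogen, 1 chlorine and 1 hydrogen-bond acceptor. The methyl comparison now rests on two different aromatic groups, since a 36-fold lower number from compound 2 to compound 3 (1.56 log units; beyond the scatter) stands alongside a 32-fold higher number from compound 1 to compound 2 (1.50 log units; beyond the scatter) and both steps are large, with compound 2 apart from compound 1 and compound 3 on this assay. No evidence in hand accounts for either the match between the two aromatic groups or their gap to methyl.

The nitrogen and the chlorine change together in compound 3, so their separate contributions stay unresolved, and plain phenyl, 2-chlorophenyl and pyridin-3-yl on the same carbonyl carbon would be the groups that separate them. From the compounds shown here alone, whether an aromatic ring is needed at all also stays open, as a cyclohexyl group or a longer chain such as n-butyl in this place could fall with compound 1 and compound 3 or with compound 2.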